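From pentyl to isopentyloxy on the shared core

A few compounds are considered here, and "the series" means these few. Any claim that something is new, unique, unknown or untested is made for them only; others in the source may bear on it.

In a functional assay on brain (Rattus norvegicus, strain Wistar) for inhibition (on this read-out higher numbers stand for weaker inhibition and lower numbers for stronger inhibition), compound 3 `CCCCCc1ccc(-c2c(C)[nH]c(=O)n2C)cc1` gives 5900 nM with a pentyl group on the shared core. The butyl member compound 1 `CCCCc1ccc(-c2c(C)[nH]c(=O)n2C)cc1` gives 10700 nM and the methoxy member compound 2 `COc1ccc(-c2c(C)[nH]c(=O)n2C)cc1` gives 147000 nM by comparison. Against the methoxy member, a 25-fold lower number from compound 2 to compound 3 (1.40 log units; beyond the scatter) marks a clear separation for the pentyl member.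

Compound 4 `Cc1[nH]c(=O)n(C)c1-c1ccc(OCCC(C)C)cc1` differs from compound 3 by isopentyloxy in place of pentyl on an aromatic carbon with isopentyloxy in place of pentyl on an aromatic carbon. Among the measured compounds shown here, with methoxy in place of butyl the series showed a 14-fold higher number from compound 1 to compound 2 (1.14 log units; beyond the scatter) as its other large step, so the only group joined through oxygen so far goes with the high number. No long chain joined through oxygen and no branched chain has been measured, which leaves the estimate loose. Compound 4 carries a long chain like compound 1 and compound 3, and the gap of a 1.8-fold lower number from compound 1 to compound 3 (0.26 log units; within the scatter) between those two is small, so no step beyond the scatter is expected in this assay here. The expected change is a 1.2-fold lower number from compound 3 to compound 4 (0.07 log units; within the scatter) on this estimate. For compound 4 the estimated value is 5000 nM within an expected range from 1800 nM to 16000 nM pending measurement.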

Compound 4, half-maximal inhibitory concentration: 6600 nM
The estimate for compound 4 lay 1.3-fold (0.12 log units) below the measured number; low and high end bracket the measured number.
By their numbers in this assay, from the lowest: compounds 3, 4 and 1 (each within the scatter of the next); then compound 2.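

In this assay a chain joined through oxygen at this position does not by itself go with the high number: a 1.1-fold higher number from compound 3 to compound 4 (0.05 log units; within the scatter) places the isopentyloxy member level with the pentyl member, and a 1.6-fold lower number from compound 1 to compound 4 (0.21 log units; within the scatter) places it level with the butyl member too. The high number of compound 2 therefore follows the short methoxy group rather than the joining oxygen alone, as the ether pair shows with a 22-fold lower number from compound 2 to compound 4 (1.35 log units; beyond the scatter), and the branched chain of compound 4 stands within the scatter of the straight chains of compound 1 and compound 3. No measured evidence at hand bears on why the chains behave this way.

The compounds shown leave open how much the joining oxygen and the branch each count on their own, as compound 4 carries both at once and a straight pentyloxy chain would be needed to separate them. Also open, from the compounds shown here alone, is whether a longer chain such as octyl, or a chain ending in an amine or a carboxylic acid, would hold the number at this position.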